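This account rests on a few compounds, and the source may have more. Where it says the series, first, only, none or still open, it means among the compounds named here.

Working notes on a small series sharing one core. Compound 1 is `Cc1c(Cc2c(F)cccc2F)nc(SCc2ccc([N+](=O)[O-])cc2)[nH]c1=O`. In an ADME assay on MT4 cells (Homo sapiens) for cytotoxicity, read by MTT assay (a lower number here means that less compound is tolerated, a higher number that more compound is tolerated), compound 1 gives > 37000 nM, which is a limit of the assay and not a number. Compound 2 is `O=C(CSc1nc(Cc2c(Cl)cccc2Cl)cc(=O)[nH]1)c1ccccc1`. In this assay compound 2 gives > 12000 nM, again a limit rather than a number. Going by the values given here, compound 1 thus stands only at a limit, and the one further value shown is a limit as well, so the two values show no ordering between them. Among the compounds with values here, no step between measured compounds is available, and nothing in the numbers points to a direction for any change on this core.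

Compound 3 is `Cc1c(Cc2c(F)cccc2F)nc(SCC(=O)c2ccc(F)cc2)[nH]c1=O`. It differs from compound 1 as follows: (4-fluorophenyl)carbonyl in place of 4-nitrophenyl on a saturated chain carbon bound to a sulfur. With both measured compounds sitting at limits, as the limit of > 12000 nM in this assay, at which 1 of the 2 values shown sits, and the limit of > 37000 nM in this assay, at which 1 of the 2 values shown sits, record, no movement beyond the scatter is expected in this assay from this change. The expected step is a step that the limit leaves unreadable from compound 1 to compound 3, none beyond the scatter. Compound 3 is estimated at 40000 nM, with a range from 15000 nM to 100000 nM, and most likely the assay again reports only a limit for it.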

Compound 3, half-maximal cytotoxic concentration: > 62000 nM
Compound 3 was reported as a limit; the forecaster's own chance of this, stated with the estimate: 80%; middle value at least 1.5-fold (0.19 log units) away from the limit.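

In this assay compound 3 gives > 62000 nM, which is a limit of the assay and not a number. Compound 1 also stands at a limit, so the step between compound 1 and compound 3 cannot be read. The compounds shown leave open whether (4-fluorophenyl)carbonyl in place of 4-nitrophenyl shifts the half-maximal cytotoxic concentration at all, and in which direction.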